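The source may hold more compounds than are shown below. What is called first, only, known or untested is meant among the compounds shown, and "the series" means these compounds.

Measured so far in a physicochemical assay for solubility, in phosphate buffer, at pH 7.4 (a higher number here means a more soluble compound, a lower number a less soluble compound), are these compounds.
- compound 1 (`CCOC(=O)c1c(-c2cccc([N+](=O)[O-])c2)[nH]c2cc(OC)ccc2c1=O`) gives 13000 nM as a number
- compound 2 (`CCOC(=O)c1c(-c2cccc(C(F)(F)F)c2)[nH]c2cc(OC)ccc2c1=O`) gives 19000 nM as a number
- compound 3 (`CCOC(=O)c1c(-c2ccccc2C)[nH]c2cccc(OC)c2c1=O`) gives > 100000 nM as a limit of the assay, not a number

For the measured compounds named here, compound 1 and compound 2 are the only two with numbers, and they lie within the scatter of each other, so compound 1 holds no clear rank. Going by the values given here, compound 3 stands at a limit (the limit of > 100000 nM in this assay, at which 1 of the 3 values shown sits) and differs from compound 1 in more than one place, which leaves no step to carry over.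

Compound 4 (`CCOC(=O)c1c(-c2ccc(OC)cc2)[nH]c2cc(OC)ccc2c1=O`) is not yet measured. Its change from compound 1 is 4-methoxyphenyl in place of 3-nitrophenyl on an aromatic carbon, next to the ring nitrogen and ortho to an ethoxycarbonyl group (4-methoxyphenyl in place of 3-nitrophenyl on an aromatic carbon). Among the compounds with values here, the one measured step that bears on this is a 1.5-fold higher number from compound 1 to compound 2 (0.16 log units; within the scatter) with trifluoromethyl in place of nitro on the same phenyl ring. That single step is small, and a change of similar size is expected here in this assay with no firm direction. The expected step is a 1.2-fold higher number from compound 1 to compound 4 (0.06 log units; within the scatter) and nothing beyond the scatter is expected. For compound 4 the estimated value is 15000 nM with an expected range from 6000 nM to 40000 nM on this thin evidence.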

Compound 4, solubility: 8000 nM
Compound 4: middle estimate off by 1.9-fold (0.27 log units), on the high side, and the stated range covers the measured number.
By their numbers in this assay, from the lowest: compounds 4, 1 and 2 (each within the scatter of the next, the first and the last beyond it). At a limit, above all of these: compound 3.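

In this assay, the new step reads a 1.6-fold lower number from compound 1 to compound 4 (0.21 log units; within the scatter), so exchanging the whole substituted phenyl group on the aromatic carbon next to the ring nitrogen, not just one substituent on the same phenyl ring, still gives a difference that cannot be told from the scatter. The three compounds with numbers do now show some spread at this position: compound 2 gives 19000 nM and compound 4 gives 8000 nM, and this pair lies beyond the scatter, though each stays within the scatter of compound 1. None of the information at hand gives a cause for the new step or for that spread.

Compound 3 stands at > 100000 nM, a limit of the assay and not a number, and it differs from the other compounds in more than one place, so its value cannot be tied to any single change. On these data alone, it remains open whether an amine or a carboxylic acid on this phenyl ring, or a carboxylic acid in place of the ethoxycarbonyl group, would give a step in this assay clearly beyond the scatter.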